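Swapping the dichlorophenyl arm for a methylphenyl one

The compounds below may be only part of what the source reports. "The series", "measured", "known", "first", "only" and "open" are said of these compounds alone.

Measured so far:
- compound 1, `COc1ccccc1/C=c1/[nH]c(=O)/c(=C\c2cccc(Cl)c2Cl)[nH]c1=O`: "not active" (no number reported), no number reported
- compound 2, `C=CCn1c(=O)/c(=C\c2cccc(Cl)c2Cl)[nH]c(=O)/c1=C\c1ccccc1OC`: 1600 nM

Two compounds share the same core and were tested in a functional assay on HeLa cells (Homo sapiens) for cytotoxicity, read by CCK-8 assay, with a stated time of 72 h; a lower number here means a stronger inhibitor, a higher number a weaker inhibitor. Compound 1 was recorded as "not active" (no number reported), with no number reported at all. Compound 2, in this assay, gives 1600 nM, the only numerical result available, so there is nothing to compare it against yet.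

Compound 3, `C=CCn1c(=O)/c(=C\c2cccc(C)c2)[nH]c(=O)/c1=C\c1ccccc1OC`, has not been measured. It differs from compound 2 in one place: 3-methylphenyl in place of 2,3-dichlorophenyl on a double-bonded chain carbon bound to an aromatic carbon. Going by the values given here, no measured pair shows what this kind of change does, so the expectation rests only on compound 2 itself. A moderate weakening, somewhat beyond the usual scatter, is expected, since the two chlorines are lost and only a single methyl comes in. Compound 3 is therefore estimated at 4000 nM, within 1200 nM to 15000 nM, a step of a 2.5-fold higher number from compound 2 to compound 3 (0.40 log units; beyond the scatter) expected from the starting value.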

Compound 3, half-maximal inhibitory concentration: 19300 nM
Compound 3: middle estimate off by 4.8-fold (0.68 log units), on the low side; measured number outside the range, above it.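

In this assay, putting 3-methylphenyl in place of 2,3-dichlorophenyl gives a 12-fold higher number from compound 2 to compound 3 (1.08 log units; beyond the scatter), so compound 3 is a much weaker inhibitor than compound 2. Going by these compounds alone, this is the first measured pair, and it shows that the aromatic group on this double-bonded chain carbon has a strong influence on the cytotoxicity read-out, with the shared core and the rest of the molecule unchanged. Nothing measured here explains why the number rises so far.

Since the two chlorines leave and the methyl enters in a single step, this pair cannot separate the loss of the chlorines from the arrival of the methyl. As far as these compounds go, how a plain phenyl, or a phenyl carrying an amine or a carboxylic acid, would behave at this place also remains open.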